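This account rests on a few compounds, and the source may have more. Where it says the series, first, only, none or still open, it means among the compounds named here.

Working notes on the series.

Two compounds have readings so far. Compound 1 `COc1cc(C)cc(-c2nn(CC#N)cc2-c2ccc(-c3cccc(C(C)=O)c3)nc2)c1` gives 96% in a functional assay on SW-620 cells (Homo sapiens) for cytotoxicity, read by sulforhodamine B assay, with a stated time of 48 h, tested at 0.001 uM; a lower number here means a stronger effect, a higher number a weaker effect of the compound at the concentration tested. Compound 2 `Cc1cc(O)cc(-c2nn(CC#N)cc2-c2ccnc(-c3ccc(Oc4ccccc4)cc3)c2)c1` gives 93% in this assay. Compound 2 holds the smaller of the two readings, but its difference from compound 1 lies within the scatter, so the two cannot be separated on the activity percentage at this concentration; both sit close to an unchanged reading.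

Compound 3 `Cc1cc(O)cc(-c2nn(CC#N)cc2-c2ccnc(-c3ccc(N(C)C)cc3)c2)c1` is the next member without a reading. It differs from compound 2 in one place: dimethylamino in place of phenoxy on an aromatic carbon. Among the measured compounds shown here, no measured pair covers this kind of exchange, so there is no step to lean on.

Given that compound 2 reads 93% in this assay and compound 1 shows much the same, compound 3 is expected to stay in the same region, with the step of no change at the digits printed from compound 2 to compound 3 (within the scatter) estimated as none beyond the scatter. The estimate for compound 3 in this assay is 93%, between 80% and 103%.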

Compound 3, a percentage reported as activity, at one concentration (the size of the read-out at that concentration, not a potency): 99%
For compound 3 the middle estimate is 6 percentage points below the measured one; measured number inside the range.
By their numbers in this assay, from the lowest: compounds 2, 1 and 3 (each within the scatter of the next).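

Replacing phenoxy with dimethylamino on the aromatic carbon para to a large group gives a number 6 percentage points higher from compound 2 to compound 3 (within the scatter) in this assay. At this position, therefore, compound 2 and compound 3 cannot be separated on this reading, although the entering group has no ring and fewer heavy atoms than the one it replaces. No available measurement explains this outcome.

Going by these compounds, the reading comes from a single low concentration and is not a potency, so it remains open whether compound 2 and compound 3 would also stay together at higher concentrations. On these data alone, it is also open whether a carboxylic acid or a longer alkyl chain on this aromatic carbon would give a reading separable from those of compound 2 and compound 3.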